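Methyl for Chloro on a Shared Aryl Ketone

The compounds below may be only part of what the source reports. "The series", "measured", "known", "first", "only" and "open" are said of these compounds alone.

Compound 1 `N#Cc1c(Cl)c(Cl)c(C(C(=O)c2ccc(Cl)cc2)=C2NCCN2)c(C#N)c1Cl`: 0.8 ug/mL
Compound 2 `N#Cc1c(F)c(Cl)c(C(C(=O)c2ccc(Cl)cc2)=C2NCCN2)c(C#N)c1F`: 1.6 ug/mL
Compound 3 `Cc1ccc(C(=O)C(=C2NCCN2)c2c(Cl)c(Cl)c(C#N)c(Cl)c2C#N)cc1`: 1.4 ug/mL

In a functional assay on K562 cells (Homo sapiens) for antiproliferative activity, read by MTT assay (a lower number here means a stronger inhibitor, a higher number a weaker inhibitor), compound 1 gives 0.8 ug/mL, compound 2 gives 1.6 ug/mL and compound 3 gives 1.4 ug/mL. Compound 3 differs from compound 1 by methyl in place of chloro on an aromatic carbon, and the step is a 1.8-fold higher number from compound 1 to compound 3 (0.24 log units; within the scatter). Compound 1 and compound 2 have different cores; the difference between the two cores is not broken down here. Compound 4 `Cc1ccc(C(=O)C(=C2NCCN2)c2c(Cl)c(F)c(C#N)c(F)c2C#N)cc1` has not been measured and differs from compound 2 by methyl in place of chloro on an aromatic carbon, the same change at the same place. Since that earlier step a 1.8-fold higher number from compound 1 to compound 3 (0.24 log units; within the scatter) lies within the scatter, the expected step here is a 1.4-fold higher number from compound 2 to compound 4 (0.14 log units; within the scatter). For compound 4 the estimate in this assay is 2.2 ug/mL, expected to fall between 1 ug/mL and 5 ug/mL.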

Compound 4, half-maximal inhibitory concentration: 41.9 ug/mL
Beside the measured number, compound 4's estimate is 19-fold (1.28 log units) below it, and the stated range ends below it.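

In this assay, methyl in place of chloro on an aromatic carbon gives a 26-fold higher number from compound 2 to compound 4 (1.42 log units; beyond the scatter). The size of this step therefore does not carry over from one core to the other: the same change on two cores in this assay, a 1.8-fold higher number (0.24 log units; within the scatter) from compound 1 to compound 3 and a 26-fold higher number (1.42 log units; beyond the scatter) from compound 2 to compound 4, 15-fold (1.18 log units) apart, beyond the scatter of two such steps. Going by these compounds alone, with only two pairs, this shows that the core can strongly alter the outcome of the change, but it does not show which difference between the cores matters or how the change would behave on any further core.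

Among the compounds shown, that aromatic carbon carries only chloro or methyl. From the compounds shown here alone, how a methoxy group, an amine or a carboxylic acid in that place would fare on either core remains open.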